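Swapping an Ester Oxygen Partner for Allylsulfanyl

This account rests on a few compounds, and the source may have more. Where it says the series, first, only, none or still open, it means among the compounds named here.

Three compounds sharing a common core have been characterised in a physicochemical assay for lipophilicity; on this read-out lower numbers stand for lower lipophilicity and higher numbers for higher lipophilicity. Compound 1 `C=CC(C)OC(=O)/C=C(C)/C=C/CC(C)CCCC(C)(C)OC` gives 5.94 in this assay, the lowest of the three numbers. Compound 3 `CC(/C=C/CC(C)CCCC(C)(C)OC(C)C)=C\C(=O)OC(C)C` stands nearest, giving 6.9 in this assay, a number beyond the scatter above compound 1. Compound 2 `CCOC(=O)/C=C(C)/C=C/CC(C)CCCC(C)CC` lies furthest away, giving 7.81 in this assay, again well beyond the scatter above compound 1. Among the measured compounds shown here, no pair of these measured compounds differs in only one place, so none of their gaps can be tied to a single structural change.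

Compound 4 `C=CCSC(=O)/C=C(C)/C=C/CC(C)CCCC(C)(C)OC` has not yet been measured in this assay. It is related to compound 1 by one change: allylsulfanyl in place of (1-methylprop-2-en-1-yl)oxy on a carbonyl carbon. The group that leaves carries one more heavy atom than the group that enters, while the acceptor count and the count of double bonds outside aromatic rings are unchanged.

For the measured compounds named here, with no measured single-point step to lean on, the account expects the step from compound 1 to compound 4 in this assay to be small, a number 0.26 log units higher from compound 1 to compound 4 (within the scatter), upward but close to the usual scatter. Compound 4 is therefore estimated at 6.2 in this assay, with a range from 5.6 to 6.8.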

Compound 4, partition coefficient: 6.77
Estimate against measurement, compound 4: 0.57 log units below; the range from low to high includes it.
By their numbers in this assay, from the lowest: compound 1; then compounds 4 and 3 (each within the scatter of the next); then compound 2.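

In this assay, among the compounds shown here, allylsulfanyl in place of (1-methylprop-2-en-1-yl)oxy on a carbonyl carbon provides the first step that can be tied to one structural change, and it is modest (a number 0.83 log units higher from compound 1 to compound 4 (beyond the scatter)). This shows that the read-out responds to a change at this position, even though the entering group has 4 heavy atoms against 5 in the group that leaves, and the hydrogen-bond acceptor count and the count of double bonds outside aromatic rings stay the same. Nothing available bears on the origin of this step.

The change replaces oxygen with sulfur and also turns the branched (1-methylprop-2-en-1-yl) chain into an unbranched allyl chain, so a single step cannot show how much of the difference belongs to each part. Allyloxy or (1-methylprop-2-en-1-yl)sulfanyl on the same carbonyl carbon would separate these two parts, while allylamino would show whether a nitrogen in that place gives a similar number, and the compounds shown leave both questions open.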